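A Carbamoyl Group Placed Elsewhere on the Benzyl Ring

The compounds below may be only part of what the source reports. "The series", "measured", "known", "first", "only" and "open" are said of these compounds alone.

Compound 1 `O=c1ccc(-c2ccc3cn[nH]c3c2)cn1Cc1ccccc1`, compound 2 `NC(=O)c1ccccc1Cn1cc(-c2ccc3cn[nH]c3c2)ccc1=O` and compound 3 `O=c1ccc(-c2ccc3cn[nH]c3c2)cn1Cc1ccc(Cl)c(Cl)c1` share one core and differ only in the group carried on the benzyl arm. In an assay for inhibition of MAP kinase-interacting serine/threonine-protein kinase 1 (Homo sapiens), read by luminescence and ADP-Glo, with a stated time of 2 h (a higher number here means a weaker inhibitor, a lower number a stronger inhibitor), compound 1 gives 315 nM, compound 2 gives 878 nM and compound 3 gives 62 nM. Compound 1 thus holds the second highest number of the three, with compound 2 the nearest and compound 3 the furthest. The unmeasured compound 4 `NC(=O)c1cccc(Cn2cc(-c3ccc4cn[nH]c4c3)ccc2=O)c1` differs from compound 1 by carbamoyl in place of hydrogen on an aromatic carbon, the carbamoyl sitting at a place described as meta to a large group. The step from compound 1 to compound 2 is the one that bears on this: adding a carbamoyl at another point of the same ring gave a 2.8-fold higher number from compound 1 to compound 2 (0.45 log units; beyond the scatter). The step from compound 1 to compound 3, a 5.1-fold lower number from compound 1 to compound 3 (0.71 log units; beyond the scatter), concerns a different change and offers no direct guidance. A modest rise is therefore expected again, though the step of a 2.2-fold higher number from compound 1 to compound 4 (0.35 log units; beyond the scatter) is an estimate only. In this assay compound 4 is expected to give about 700 nM, within a range of 300 nM to 1600 nM.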

Compound 4, half-maximal inhibitory concentration: 388 nM
Beside the measured number, compound 4's estimate is 1.8-fold (0.26 log units) above it, within the range that was stated.
By their numbers in this assay, from the lowest: compound 3; then compounds 1 and 4 (each within the scatter of the next); then compound 2.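

In this assay carbamoyl in place of hydrogen, meta to a large group, gives a 1.2-fold higher number from compound 1 to compound 4 (0.09 log units; within the scatter) and so the two compounds cannot be told apart. The same group elsewhere on this ring gave a 2.8-fold higher number from compound 1 to compound 2 (0.45 log units; beyond the scatter) and the printed values differ as well, with compound 4 at 388 nM and compound 2 at 878 nM, so among these compounds the effect of adding carbamoyl depends on where it sits on the ring. No measurement shown here explains that difference between the two places.

Still open, on these data alone, is whether an amine, a carboxylic acid or a methyl ester at this place would also match compound 1. Also open, as far as these compounds go, is whether carbamoyl at this place on the 3,4-dichlorophenyl group of compound 3 would be tolerated equally well.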